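Compound 3 Against a Small Measured Step

This account rests on a few compounds, and the source may have more. Where it says the series, first, only, none or still open, it means among the compounds named here.

Measured in an ADME assay on L6 cells (Rattus norvegicus) for cytotoxicity; a lower number here means a stronger inhibitor, a higher number a weaker inhibitor:
Compound 1 `CN1CCN(CCCN2CCC3(N(C)C)CC(c4ccccc4)C2C(c2ccccc2)C3)CC1`: 54500 nM
Compound 2 `CN1CCN(CCN2CCC3(N(C)C)CC(c4ccccc4)C2C(c2ccccc2)C3)CC1`: 70300 nM

Compound 1 gives 54500 nM, and compound 2 gives 70300 nM. These two values lie within the usual scatter of each other, so the numbers do not rank the pair.

Compound 3 `CN1CCN(CCCN2CCC3(N4CCCC4)CC(c4ccccc4)C2C(c2ccccc2)C3)CC1` keeps the core of compound 1 and alters one group: pyrrolidin-1-yl in place of dimethylamino on a saturated ring carbon. Here pyrrolidin-1-yl stands in place of dimethylamino on a saturated ring carbon.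

For the measured compounds named here, only one measured step is available, a 1.3-fold higher number from compound 1 to compound 2 (0.11 log units; within the scatter). That change lies on the chain rather than at this ring carbon, so it bears on the question only indirectly. Going by the values given here, no measured compound varies the dimethylamino group, and the data therefore give no direction for this swap. On that limited evidence, no step beyond the scatter is expected in this assay. The expected step is a 1.1-fold lower number from compound 1 to compound 3 (0.04 log units; within the scatter). For compound 3 the estimated value is 50000 nM, with an expected range from 22000 nM to 110000 nM.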

Compound 3, half-maximal inhibitory concentration: 27500 nM
Compound 3: the middle estimate sits 1.8-fold (0.26 log units) above what was measured; the measured number falls inside the stated range.
By their numbers in this assay, from the lowest: compounds 3, 1 and 2 (each within the scatter of the next, the first and the last beyond it).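

For the compounds shown here, this is the first measured change at this saturated ring carbon, and in this assay putting pyrrolidin-1-yl in place of dimethylamino gives a 2.0-fold lower number from compound 1 to compound 3 (0.30 log units; within the scatter). The entering group has 5 heavy atoms and a five-membered ring, while the leaving group has 3 heavy atoms and no ring, yet the step stays within the scatter, so the two numbers do not rank compound 1 and compound 3. At this position, then, the shown change from an open dimethylamino group to a ring of the same hydrogen-bond count gives no separation in this assay, and nothing measured here offers a reason for the size of the step.

As far as these compounds go, it remains open whether a piperidin-1-yl or morpholin-4-yl group, or a plain primary amine, on this same ring carbon would give a step beyond the scatter. From the compounds shown here alone, it is also open whether pyrrolidin-1-yl would give a similar step on the core of compound 2, where the 4-methylpiperazin-1-yl group sits on a different chain.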